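The source may report more compounds than this note shows. Statements on the series, on what has been measured and on what is new or still open speak of the compounds shown alone.

Compound 1 `CCCCCC/C=C/c1cc(C)oc(=O)c1` gives > 50000 nM in a functional assay on A2780 cells (Homo sapiens) for inhibition (a higher number here means a weaker inhibitor, a lower number a stronger inhibitor), a limit of the assay rather than a number.
Compound 2 `Cc1cc(-c2ccccc2)cc(=O)o1` gives > 50000 nM in this assay, again a limit.
Compound 3 `CCCCc1cc(C)oc(=O)c1` gives > 50000 nM in this assay, also a limit.

Compound 3 therefore stands at the edge of what this assay can report, and it is not alone there: the limit of > 50000 nM in this assay, at which 3 of the 3 values shown sit. Going by the values given here, no step between measured compounds is available, since none differ in a single place. Compound 4 `CCc1cc(C)oc(=O)c1` is the next compound, and it differs from compound 3 as follows: hydrogen in place of ethyl on a saturated chain carbon, two bonds along the chain from an aromatic carbon. With every shown value sitting at the limit, the step from compound 3 to compound 4 is expected to be a step that the limit leaves unreadable from compound 3 to compound 4, that is, none beyond the scatter. Compound 4 is accordingly expected to give 100000 nM in this assay, with a range from 50000 nM to 300000 nM and most likely only a limit again.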

Compound 4, half-maximal inhibitory concentration: > 50000 nM
Compound 4 was reported as a limit (the forecaster's own chance of this, stated with the estimate: 85%); the middle value is on the limit's open side.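

No step can be read between compound 3 and compound 4, since both are reported only as limits: the limit of > 50000 nM in this assay, at which 4 of the 4 values shown sit.

The compounds shown leave open which change to the shared core, if any, would bring a readable value in this assay.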